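From 3-methoxyphenyl to 4-chlorophenyl on the ring nitrogen

This account rests on a few compounds, and the source may have more. Where it says the series, first, only, none or still open, it means among the compounds named here.

Compound 1 `COc1ncc(-c2ccc3c(c2)N(c2ccc(F)cc2)C(=O)CO3)cc1NS(=O)(=O)c1ccc(F)cc1`: > 40000 nM
Compound 2 `COc1cccc(N2C(=O)COc3ccc(-c4cccc(NS(=O)(=O)c5ccc(F)cc5)c4)cc32)c1`: > 40000 nM

In a functional assay on A-375 cells (Homo sapiens) for antiproliferative activity, read by MTT assay, with a stated time of 72 h (on this read-out lower numbers stand for stronger inhibition and higher numbers for weaker inhibition), compound 2 gives > 40000 nM, which is a limit of the assay and not a number. Compound 1 and compound 2 alike stand at the limit of > 40000 nM in this assay, at which 2 of the 2 values shown sit. Compound 3 `O=C1COc2ccc(-c3cccc(NS(=O)(=O)c4ccc(F)cc4)c3)cc2N1c1ccc(Cl)cc1` has 4-chlorophenyl in place of 3-methoxyphenyl on an amide-type nitrogen in a ring. Among the measured compounds shown here, no measured step gives this change a size, so no step beyond the scatter, in either direction, is expected in this assay. The estimated step is a number no higher from compound 2 to compound 3 (the limit leaves the size open). Compound 3 is expected at 40000 nM, with an estimated range from 15000 nM to 80000 nM.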

Compound 3, half-maximal inhibitory concentration: 32500 nM
Estimate against measurement, compound 3: 1.2-fold (0.09 log units) above, and the stated range covers the measured number.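

In this assay compound 3 gives 32500 nM, a measured number. Changing 3-methoxyphenyl to 4-chlorophenyl on the amide-type nitrogen in a ring gives an at least 1.2-fold lower number from compound 2 to compound 3 (0.09 log units; that floor lies within the scatter), so this change shows no gain beyond the scatter, though its true size cannot be read. Compound 1 and compound 2 remain at a limit of the assay: the limit of > 40000 nM in this assay, at which 2 of the 3 values shown sit.

Going by these compounds, whether a methyl group or a phenyl carrying a carboxylic acid on that nitrogen would move the number beyond the scatter stays open.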